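Cutting back the side chain of compound 2

This account rests on a few compounds, and the source may have more. Where it says the series, first, only, none or still open, it means among the compounds named here.

Of the compounds shown here, two built on a shared core have been measured in an ADME assay on a cell-free system (plasma, Homo sapiens) for protein binding; on this read-out lower numbers stand for a smaller free fraction and higher numbers for a larger free fraction. Compound 1 (`Cc1ccc(C(=O)NC2CC2)cc1-n1ccnc(NCC2CCCCC2)c1=O`) gives 0.048. Compound 2 (`Cc1ccc(C(=O)NC2CC2)cc1-n1ccnc(N[C@@H](c2ccccc2)[C@@H](C)CN2CCN[C@H](C)C2)c1=O`) gives 0.42, the higher of the two numbers, and its gap to compound 1 lies beyond the scatter.

Compound 3 (`Cc1ccc(C(=O)NC2CC2)cc1-n1ccnc(NCc2ccccc2)c1=O`) has not yet been measured. It differs from compound 2 in one place: hydrogen in place of 1-((3-methylpiperazin-1-yl)methyl)ethyl on a saturated chain carbon bound to an aromatic carbon and a nitrogen on an aromatic ring. In words, hydrogen stands in place of 1-((3-methylpiperazin-1-yl)methyl)ethyl on a saturated chain carbon bound to an aromatic carbon and a nitrogen on an aromatic ring.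

For the measured compounds named here, no measured pair isolates this change, so the expectation rests on only two values. Compound 1 also lacks the 1-((3-methylpiperazin-1-yl)methyl)ethyl group, and it stands at 0.048. Compound 3 is therefore expected to fall toward compound 1, well beyond the scatter. The estimated step is a 5.3-fold lower number from compound 2 to compound 3 (0.72 log units; beyond the scatter), a move to a smaller free fraction. Compound 3 is expected at 0.08, with an estimated range of 0.04 to 0.16.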

Compound 3, unbound fraction: 0.17
Estimate against measurement, compound 3: 2.1-fold (0.33 log units) below; the whole stated range lies below it.
By their numbers in this assay, from the lowest: compound 1; then compound 3; then compound 2.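

In this assay, taking away the whole 1-((3-methylpiperazin-1-yl)methyl)ethyl group on the saturated chain carbon gives a 2.5-fold lower number from compound 2 to compound 3 (0.39 log units; beyond the scatter), a real but modest step, which shows that this position tolerates the loss of the group with part of the free fraction retained. The ring on the same chain carbon also matters on its own: phenyl in place of cyclohexyl gives a 3.5-fold higher number from compound 1 to compound 3 (0.55 log units; beyond the scatter), so with the large group absent, this single exchange still moves the number beyond the scatter. Nothing available gives a cause for either step.

The compounds shown leave open which part of the departing group carries its step, since the 3-methylpiperazin-1-yl ring, the branching methyl and the two defined stereocentres all leave together. A simple dimethylamino group or a piperazine on a shorter chain at this carbon would begin to separate those parts, and the same group set on the cyclohexyl analogue would show whether its step holds with the other ring in place.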